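Notes on methyl in place of tert-butyl

The source may report more compounds than this note shows. Statements on the series, on what has been measured and on what is new or still open speak of the compounds shown alone.

Measured so far:
compound 1 `C=C1CN/C(=N/c2ccccc2)S1`: > 100000 nM
compound 2 `COc1ccc(/C=C2\S/C(=N\c3ccc(C(C)(C)C)cc3)N(C)C2=O)cc1`: > 100000 nM

Both entries come from a functional assay on MCF7 cells (Homo sapiens) for antiproliferative activity, read by MTT assay, with a stated time of 72 h; on this read-out higher numbers stand for weaker inhibition and lower numbers for stronger inhibition. Compound 1 reads > 100000 nM, which is a limit of the assay and not a number. Compound 2 reads > 100000 nM, which is also a limit and not a number. Among the measured compounds shown here, the series so far comes down to the limit of > 100000 nM in this assay, at which 2 of the 2 values shown sit. For the measured compounds named here, no step between measured compounds is available to serve as a guide.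

Next is compound 3 `COc1ccc(/C=C2\S/C(=N\c3ccc(C)cc3)N(C)C2=O)cc1`, which carries methyl in place of tert-butyl on an aromatic carbon. The expectation in this assay is a small shift towards stronger inhibition, or none beyond the scatter. It rests only on compound 2 at > 100000 nM, a limit, so it is loose. The estimated step of an at least 1.4-fold lower number from compound 2 to compound 3 (0.15 log units; that floor lies within the scatter) is expected to be small. Compound 3 is estimated at 70000 nM. The expected range for compound 3 runs from 20000 nM to 150000 nM, and a further limit in place of a number would be no surprise.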

Compound 3, half-maximal inhibitory concentration: > 100000 nM
Compound 3 was reported as a limit; the forecaster's own chance of this, stated with the estimate: 60%; middle value at least 1.4-fold (0.15 log units) away from the limit.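

No step can be read between compound 2 and compound 3 in this assay, with both reported only as limits and not as numbers. The series as shown stays at a single limit: the limit of > 100000 nM in this assay, at which 3 of the 3 values shown sit.

The compounds shown leave open whether methyl and tert-butyl differ at all in this assay, and which change to the shared core would give a measurable number.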